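Two Close Values and an Unmeasured Hydroxyphenyl Urea

This account rests on a few compounds, and the source may have more. Where it says the series, first, only, none or still open, it means among the compounds named here.

Compound 1 `COc1cc(NC(C)CCCNC(=O)Nc2cccc(O)c2)c2ncccc2c1` gives 32000 nM
Compound 2 `COc1cc(NC(C)CCCNC(=O)Nc2cccc(C(F)(F)F)c2)c2ncccc2c1` gives 19000 nM

Both values come from a functional assay on CCRF-CEM cells (Homo sapiens) for inhibition, read by MTT assay, with a stated time of 72 h; a higher number here means a weaker inhibitor, a lower number a stronger inhibitor. For the measured compounds named here, the only measured step between the two compounds is a 1.7-fold lower number from compound 1 to compound 2 (0.23 log units; within the scatter), with trifluoromethyl in place of hydroxy on an aromatic carbon. Compound 2 therefore stands within the scatter of compound 1, and the two cannot be told apart on these numbers.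

Compound 3 `COc1cc(NC(C)CCCNC(=O)Nc2ccc(O)cc2)c2ncccc2c1` has not yet been measured. It is reached from compound 2 by putting 4-hydroxyphenyl in place of 3-(trifluoromethyl)phenyl on an amide-type nitrogen. Going by the values given here, only one measured step bears on this change, and it also exchanges trifluoromethyl and hydroxy, though in the opposite direction. Among the compounds with values here, no step beyond the scatter is expected in this assay because a 1.7-fold lower number from compound 1 to compound 2 (0.23 log units; within the scatter) is the only such exchange on record. The data hold no measurement that isolates the effect of where the hydroxy group sits, so the range is kept wide. The expected change is a 1.3-fold higher number from compound 2 to compound 3 (0.12 log units; within the scatter), with no clear direction. For compound 3 the estimated value is 25000 nM, with an expected range from 10000 nM to 60000 nM.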

Compound 3, half-maximal inhibitory concentration: 23000 nM
Beside the measured number, compound 3's estimate is 1.1-fold (0.04 log units) above it; the measured number falls inside the stated range.
By their numbers in this assay, from the lowest: compounds 2, 3 and 1 (each within the scatter of the next).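

In this assay, replacing the 3-(trifluoromethyl)phenyl on the amide-type nitrogen with 4-hydroxyphenyl gives a 1.2-fold higher number from compound 2 to compound 3 (0.08 log units; within the scatter), so this exchange of groups does not separate the two compounds. The earlier compounds shown here offered no pair that isolated where the hydroxy group sits, and the new pair supplies one: 4-hydroxyphenyl in place of 3-hydroxyphenyl gives a 1.4-fold lower number from compound 1 to compound 3 (0.14 log units; within the scatter), and on these numbers the two placements cannot be told apart. All three groups tried at this position therefore remain indistinguishable in this assay, and no available evidence accounts for this outcome.

The compounds shown all carry a six-membered aromatic ring of carbon only on this nitrogen, so it remains open whether a different kind of group there, such as a carboxylic acid, an amine or a longer chain, would produce a step beyond the scatter. They also share one core, which leaves open whether a change elsewhere in the molecule would shift the number in this assay more than any of these exchanges has.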